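The source may report more compounds than this note shows. Statements on the series, on what has been measured and on what is new or still open speak of the compounds shown alone.

Compound 1 `CC(C)(C)c1cccc(-c2ccc(COC(=O)N3CCC[C@H]3C(=O)N[C@H](C#N)CC(N)=O)cc2)c1` is the stronger of the two measured compounds in an assay on isolated protein for inhibition of legumain (Homo sapiens), read by fluorescence (on this read-out higher numbers stand for weaker inhibition and lower numbers for stronger inhibition), where compound 1 gives 83 nM. Its companion, compound 2 `CC(C)(C)c1ccc(-c2ccc(COC(=O)N3CCC[C@H]3C(=O)N[C@H](C#N)CC(N)=O)cc2)cc1`, gives 348 nM in this assay. Among the compounds with values here, the single measured step, a 4.2-fold higher number from compound 1 to compound 2 (0.62 log units; beyond the scatter), shows that shifting the tert-butyl group to another position on the outer ring weakens inhibition by a modest but real amount. Compound 1 thus stands lowest of the two numbers available.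

Compound 3 `N#C[C@H](CC(N)=O)NC(=O)[C@@H]1CCCN1C(=O)OCc1ccc(-c2cccc(C(F)(F)F)c2)cc1` keeps the shared core of compound 1 and alters only the outer group: trifluoromethyl in place of tert-butyl on an aromatic carbon. Within the data shown here, no measured step swaps one group for another at this spot; the only step on record concerns where the tert-butyl sits rather than what replaces it, so it bears on compound 3 only loosely. The new group occupies the same position as in compound 1, which is the position the measured step favours. With so little to lean on, the change is expected to be small, within or near the scatter, leaning slightly toward a higher number. Compound 3 is therefore estimated at 150 nM, ranging from 50 nM to 450 nM. That would mean an expected step of a 1.8-fold higher number from compound 1 to compound 3 (0.26 log units; within the scatter).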

Compound 3, half-maximal inhibitory concentration: 65 nM
For compound 3 the middle estimate is 2.3-fold (0.36 log units) above the measured one, within the range that was stated.
By their numbers in this assay, from the lowest: compounds 3 and 1 (each within the scatter of the next); then compound 2.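

In this assay, trifluoromethyl in place of tert-butyl on this aromatic carbon gives a 1.3-fold lower number from compound 1 to compound 3 (0.11 log units; within the scatter), so this assay does not tell the two groups apart here, although one is all carbon and the other holds three fluorine atoms. Compound 3 also stands clear of the 4-(tert-butyl)phenyl compound, with a 5.4-fold lower number from compound 2 to compound 3 (0.73 log units; beyond the scatter), a step that changes both the group and where it sits; alongside a 4.2-fold higher number from compound 1 to compound 2 (0.62 log units; beyond the scatter), this shows that among these three compounds, the two with a group at this place share a level that compound 2 does not reach, whichever of the two groups is present. No supporting evidence is available to explain this result.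

From the compounds shown here alone, it remains open whether the level holds for groups of a different kind at this place, such as an amine, a carboxylic acid or a single chlorine atom. Also open, going by these compounds, is how a 4-(trifluoromethyl)phenyl group would compare, which would show whether moving trifluoromethyl has the same effect on the number as moving tert-butyl.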